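This account rests on a few compounds, and the source may have more. Where it says the series, first, only, none or still open, it means among the compounds named here.

Of the compounds shown here, three sharing one core have been measured so far in a physicochemical assay for lipophilicity, read by HPLC; a higher number here means a more lipophilic compound, a lower number a more polar compound. Compound 1 `CC(=O)NC[C@H]1CN(c2ccc(OC[C@@H](O)CNc3ccccc3)c(F)c2)C(=O)O1` gives 1.42, the lowest of the three numbers. Compound 2 `CC(=O)NC[C@H]1CN(c2ccc(OC[C@@H](O)CNc3ccc(C#N)cc3)c(F)c2)C(=O)O1` gives 2.12, and compound 3 `CC(=O)NC[C@H]1CN(c2ccc(OC[C@H](O)CNc3cc(C(F)(F)F)cc(C(F)(F)F)c3)c(F)c2)C(=O)O1` gives 3.01.

The next compound to be measured is compound 4 `CC(=O)NC[C@H]1CN(c2ccc(OC[C@H](O)CNc3ccccn3)c(F)c2)C(=O)O1`. Its structural change from compound 1 is 1-hydroxy-2-((pyridin-2-yl)amino)ethyl in place of 2-anilino-1-hydroxyethyl on a saturated chain carbon bound to an oxygen on an aromatic ring. Put simply, one carbon of the aromatic ring is replaced by a nitrogen, and the count of hydrogen-bond acceptors goes up.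

Going by the values given here, only one measured step offers a guide: a number 0.70 log units higher from compound 1 to compound 2 (beyond the scatter), made by placing cyano in place of hydrogen on an aromatic carbon. That step adds a group to the ring and leaves the ring atoms themselves unchanged, so it bears on the new change only loosely. It gives a rough sense of how far a single change can move this assay in this series, but it does not set the direction. Among the compounds with values here, no measured compound has a nitrogen in this ring, so the direction is a judgement from the structural change alone.

A modest fall is expected, an estimated step of a number 0.32 log units lower from compound 1 to compound 4 (beyond the scatter). For compound 4 the expected value is 1.1, with an estimated range from 0.7 to 1.5.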

Compound 4, partition coefficient: 1.6
Compound 4: the middle estimate sits 0.50 log units below what was measured, outside the stated range (above it).
By their numbers in this assay, from the lowest: compounds 1 and 4 (each within the scatter of the next); then compound 2; then compound 3.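

In this assay the new step reads a number 0.18 log units higher from compound 1 to compound 4 (within the scatter), so exchanging 2-anilino-1-hydroxyethyl for 1-hydroxy-2-((pyridin-2-yl)amino)ethyl, with one more hydrogen-bond acceptor by count, gives no change that can be told apart from repeat-measurement scatter. Going by these compounds alone, the earlier compounds showed only that a group added to this aromatic ring can shift the number, as in the step of a number 0.70 log units higher from compound 1 to compound 2 (beyond the scatter); the new result shows that, for this one pair, replacing a ring carbon with a nitrogen leaves compound 4 level with compound 1 within the scatter. No measurement shown here explains why the two compounds read alike.

On these data alone, it remains open whether a ring nitrogen would also leave the number unchanged in a ring carrying a nitrile or a trifluoromethyl group, since the ring of compound 4 has neither. How this assay responds to a carboxylic acid or an amine on this aromatic ring, in place of those groups, is also an open question.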